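The source may hold more compounds than are shown below. What is called first, only, known or untested is meant among the compounds shown, and "the series" means these compounds.

Values measured in a functional assay on BT-483 cells (Homo sapiens) for cytotoxicity, read by MTT assay, with a stated time of 24 h; a lower number here means a stronger inhibitor, a higher number a weaker inhibitor:
- Compound 1 `CCNc1cc(-c2ccc(NC(=O)Nc3ccc(OC)cc3)cc2C)ccn1`: 25800 nM
- Compound 2 `CCNc1cc(-c2ccc(NC(=O)Nc3ccc(OC)cc3)cc2C(F)(F)F)ccn1`: 17600 nM
- Compound 3 `CCNc1cc(-c2ccc(NC(=O)Nc3ccc(OC)cc3)cc2OC)ccn1`: > 30000 nM

For compound 3, the reading > 30000 nM is a limit and not a number.

Compound 4 `CCNc1cc(-c2ccc(NC(=O)Nc3ccccc3Cl)cc2OC)ccn1` differs from compound 3 in a single place: 2-chlorophenyl in place of 4-methoxyphenyl on an amide-type nitrogen. In words, 2-chlorophenyl stands in place of 4-methoxyphenyl on an amide-type nitrogen.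

For the measured compounds named here, no measured step touches this group. All three measured steps exchange a different group on an aromatic carbon and keep 4-methoxyphenyl unchanged: a 1.5-fold lower number from compound 1 to compound 2 (0.17 log units; within the scatter), an at least 1.1-fold higher number from compound 1 to compound 3 (0.06 log units; that floor lies within the scatter) and an at least 1.7-fold higher number from compound 2 to compound 3 (0.23 log units; that floor lies within the scatter). Each lies within the scatter, so they give only a weak guide to the new change, and no direction can be expected with confidence.

Going by the values given here, the only numbers available are compound 1 at 25800 nM and compound 2 at 17600 nM, so a result in that region is the working expectation. The expected change is an at least 1.5-fold lower number from compound 3 to compound 4 (0.17 log units; that floor lies within the scatter), which is no firm step beyond the scatter. The estimate for compound 4 is 20000 nM, with an expected range from 8000 nM to 40000 nM.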

Compound 4, half-maximal inhibitory concentration: > 30000 nM
Compound 4 ended at the assay's limit; the forecaster's own chance of this, stated with the estimate: 35%; middle value at least 1.5-fold (0.17 log units) from the limit.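

Compound 3 and compound 4 both end at a limit and not at a number, so no step between them can be read: the limit of > 30000 nM in this assay, at which 2 of the 4 values shown sit.

The compounds shown leave open whether 2-chlorophenyl in place of 4-methoxyphenyl on an amide-type nitrogen changes the reading at all, in which direction, and by how much.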